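Swapping a difluorophenyl for a bromophenyl on the triazole arm

The compounds below may be only part of what the source reports. "The series", "measured", "known", "first", "only" and "open" are said of these compounds alone.

Of the compounds shown here, three built on a shared core have been tested in a functional assay on A549 cells (Homo sapiens) for antiproliferative activity, read by MTT assay, with a stated time of 72 h; on this read-out lower numbers stand for stronger inhibition and higher numbers for weaker inhibition. Compound 1 `O=C1O/C(=C\Cn2cc(-c3cc(F)cc(F)c3)nn2)C(OCc2ccccc2)=C1OCc1ccccc1` carries a 3,5-difluorophenyl on the five-membered aromatic ring with 3 nitrogen and a double bond in the linking chain; in this assay compound 1 reaches only a limit, > 100000 nM. Compound 3 `O=C1O/C(=C\Cn2cc(-c3cc(C(F)(F)F)cc(C(F)(F)F)c3)nn2)C(OCc2ccccc2)=C1OCc1ccccc1` keeps that double bond and bears a bis(trifluoromethyl)phenyl; in this assay compound 3 likewise gives only a limit, > 100000 nM. The picture so far is shaped by the limit of > 100000 nM in this assay, at which 2 of the 3 values shown sit. Among the compounds with values here, compound 2 `O=C1O[C@H]([C@@H](O)Cn2cc(-c3cc(F)cc(F)c3)nn2)C(OCc2ccccc2)=C1OCc1ccccc1`, with a saturated linker bearing a hydroxyl, is the single compound to yield a number: in this assay compound 2 gives 41200 nM, and it therefore stands alone as the only measured point among the three.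

Compound 4 `O=C1O[C@H]([C@@H](O)Cn2cc(-c3ccc(Br)cc3)nn2)C(OCc2ccccc2)=C1OCc1ccccc1` keeps the core and linker of compound 2 and differs in one place: 4-bromophenyl in place of 3,5-difluorophenyl on an aromatic carbon. Within the data shown here, no step between measured compounds exists to calibrate this change. Among the measured compounds shown here, on the single number available, compound 2 at 41200 nM, the expected step of a 1.0-fold lower number from compound 2 to compound 4 (0.01 log units; within the scatter) is small and within the usual scatter, in either direction. Compound 4 is therefore estimated at 40000 nM, with a plausible range from 13000 nM to 100000 nM, and a real chance of a limit rather than a number.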

Compound 4, half-maximal inhibitory concentration: 750 nM
Compound 4: the middle estimate sits 53-fold (1.73 log units) above what was measured; the whole stated range lies above it.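

In this assay, the 4-bromophenyl in place of 3,5-difluorophenyl on an aromatic carbon of the five-membered aromatic ring with 3 nitrogen gives a 55-fold lower number from compound 2 to compound 4 (1.74 log units; beyond the scatter), with the core and the hydroxyl-bearing linker unchanged. Within the data shown here, this shows that the aryl group at this position can move the read-out strongly, something the earlier compounds could not show, as they offered no step between measured compounds. The change is also a double one, with bromine entering and both fluorines leaving, while each group remains one six-membered aromatic ring of carbon only, without a hydrogen-bond donor, a hydrogen-bond acceptor or a net charge, so this single step cannot separate the identity of the halogen from its placement on the ring.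

The compounds shown leave open whether a chlorophenyl, or a phenyl ring carrying an amine or a carboxylic acid, would hold or lose this gain. They also leave open how the 4-bromophenyl would read on the double-bond linker, where the read-out so far offers only limits: the limit of > 100000 nM in this assay, at which 2 of the 4 values shown sit.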